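Swapping One Group on a Carbonyl Carbon

The source may hold more compounds than are shown below. What is called first, only, known or untested is meant among the compounds shown, and "the series" means these compounds.

- Compound 1 `COc1ccc(-c2cnc(NC(=O)c3ncc[nH]3)n2C)cc1` gives 6.3 ug/mL
- Compound 2 `Cn1c(-c2ccccc2)cnc1NC(=O)c1ccc(F)cc1` gives 25 ug/mL

In a physicochemical assay for solubility, read by nephelometry, measured as kinetic solubility, at pH 6.5 (a lower number here means a less soluble compound, a higher number a more soluble compound), compound 1 stands lowest of the two, and its gap to compound 2 lies beyond the usual scatter. Compound 3 `COc1ccc(-c2cnc(NC(=O)c3ccc(F)cc3)n2C)cc1`, not yet measured, keeps the core of compound 1 but has 4-fluorophenyl in place of 1H-imidazol-2-yl on a carbonyl carbon. Compound 2 also carries 4-fluorophenyl there and gives a higher number (25 ug/mL), though its core differs, so only part of that gap is expected to be closed. The expected result is a small rise, about the size of the usual scatter (a 1.9-fold higher number from compound 1 to compound 3 (0.28 log units; within the scatter)). For compound 3 the estimate in this assay is 12 ug/mL (expected range 4 ug/mL to 32 ug/mL).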

Compound 3, solubility: < 1.6 ug/mL
Compound 3: no number, only a limit; the forecaster's own chance of this, stated with the estimate: 10%; middle value at least 7.5-fold (0.87 log units) away from the limit.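

In this assay, 4-fluorophenyl in place of 1H-imidazol-2-yl on a carbonyl carbon gives an at least 3.9-fold lower number from compound 1 to compound 3 (0.59 log units; beyond the scatter), so the group at this position matters, and this swap lowers the reading. Methoxy in place of hydrogen on an aromatic carbon, with 4-fluorophenyl kept, gives an at least 15-fold lower number from compound 2 to compound 3 (1.19 log units; beyond the scatter), so that second change matters as well. Compound 3 has only a limit, not a number: the limit of < 1.6 ug/mL in this assay, at which 1 of the 3 values shown sits.

Still open, going by these compounds, is the true value of compound 3, and whether the methoxy step would hold with 1H-imidazol-2-yl on the carbonyl carbon. An amine-bearing chain on that carbon is also untested in the compounds shown.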